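The source may report more compounds than this note shows. Statements on the series, on what has been measured and on what is new or still open speak of the compounds shown alone.

Compound 2 `Oc1ccc(-c2cc(-c3ccc(Cl)cc3)nc(-c3cccnc3)c2)cc1` and compound 1 `Oc1cccc(-c2cc(-c3ccc(Cl)cc3)nc(-c3ccco3)c2)c1` share one core and have both been run in a functional assay on T47D cells (Homo sapiens) for cytotoxicity, read by CCK-8 assay and cell counting, with a stated time of 2 days; on this read-out higher numbers stand for weaker inhibition and lower numbers for stronger inhibition. In this assay compound 1 gives 10500 nM. In this assay compound 2 gives 29300 nM, the higher of the two numbers, and the gap to compound 1 lies beyond the scatter; since the two structures differ in more than one place, their values are simply set side by side. Compound 3 `Oc1ccc(-c2cc(-c3ccc(Cl)cc3)nc(-c3ccco3)c2)cc1` has not yet been measured in this assay. It differs from compound 2 in a single place: furan-2-yl in place of pyridin-3-yl on an aromatic carbon. The same furan-2-yl group is carried by compound 1, which differs from compound 3 elsewhere, so the comparison is only a pointer. A move toward a lower number is expected because compound 1 gives 10500 nM in this assay. For compound 3 the estimated value in this assay is 14000 nM, with a range from 5000 nM to 40000 nM. This estimate means an expected step of a 2.1-fold lower number from compound 2 to compound 3 (0.32 log units; beyond the scatter), sitting close to the edge of the scatter rather than clearly beyond it.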

Compound 3, half-maximal inhibitory concentration: 6260 nM
The estimate for compound 3 lay 2.2-fold (0.35 log units) above the measured number, within the range that was stated.
By their numbers in this assay, from the lowest: compounds 3 and 1 (each within the scatter of the next); then compound 2.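

In this assay, the aromatic carbon next to the ring nitrogen responds to a single change: furan-2-yl in place of pyridin-3-yl gives a 4.7-fold lower number from compound 2 to compound 3 (0.67 log units; beyond the scatter), a modest step beyond the scatter that is now read apart from any other difference. 4-Hydroxyphenyl in place of 3-hydroxyphenyl gives a 1.7-fold lower number from compound 1 to compound 3 (0.22 log units; within the scatter), which lies within the scatter, so this pair shows no difference between the two hydroxyphenyl placements when furan-2-yl is present, and the gap seen earlier between two compounds differing in more than one place now has a single-place step to set against it. No measurement on hand explains why the furan-2-yl compound gives the lower number.

Going by these compounds alone, with only two groups compared at this carbon, a single step cannot show whether the lower number is particular to furan-2-yl or would also appear with thiophen-2-yl, plain phenyl or pyridin-2-yl. The 4-chlorophenyl group is the same throughout, and the compounds shown leave open what a methoxy group in place of the hydroxyl, or an amine on that ring, would do in this assay.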